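Trading One Side Chain for Another on a Shared Core

This account rests on a few compounds, and the source may have more. Where it says the series, first, only, none or still open, it means among the compounds named here.

Of the compounds shown here, three sharing one core have been measured in an assay on cells for antagonist activity at transient receptor potential cation channel subfamily V member 1 (Homo sapiens), read by FLIPR and calcium flux, with a stated time of 6 min; a higher number here means a weaker inhibitor, a lower number a stronger inhibitor. Compound 1 `CCCCN(C)c1nc(C(C)(C)C)ccc1CNC(=O)C(C)c1ccc(NS(C)(=O)=O)c(F)c1` gives 1.2 nM. Compound 2 `CC(C(=O)NCc1ccc(C(C)(C)C)nc1N1CCC(Cc2ccccc2)CC1)c1ccc(NS(C)(=O)=O)c(F)c1` gives 0.3 nM. Compound 3 `CC(C)CCOc1nc(C(C)(C)C)ccc1CNC(=O)C(C)c1ccc(NS(C)(=O)=O)c(F)c1` gives 0.8 nM. Among the compounds with values here, the only step between two compounds that differ in a single place is a 1.5-fold lower number from compound 1 to compound 3 (0.18 log units; within the scatter), so compound 1 and compound 3 lie within the scatter of each other. Compound 2 shows a lower number than compound 3, a gap beyond the scatter, and so compound 3 holds the second highest of the three numbers.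

Compound 4 `CC(C(=O)NCc1ccc(C(C)(C)C)nc1SCCCN1CCCC1)c1ccc(NS(C)(=O)=O)c(F)c1` has not yet been measured. It differs from compound 3 in one place: (3-(pyrrolidin-1-yl)propyl)sulfanyl in place of isopentyloxy on an aromatic carbon. This is the same position that changed between compound 1 and compound 3, where the step of a 1.5-fold lower number from compound 1 to compound 3 (0.18 log units; within the scatter) stayed within the scatter. Within the data shown here, no other measured step touches this position, and no measured compound carries the entering chain, so the one relevant precedent points to little movement. Compound 4 is expected to change little, with an estimated step of a 1.1-fold higher number from compound 3 to compound 4 (0.05 log units; within the scatter) and no shift beyond the scatter foreseen. The estimate for compound 4 in this assay is 0.9 nM, within a range from 0.3 nM to 3 nM.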

Compound 4, inhibition constant: 17.1 nM
Compound 4: the middle estimate sits 19-fold (1.28 log units) below what was measured, outside the stated range (above it).
By their numbers in this assay, from the lowest: compound 2; then compounds 3 and 1 (each within the scatter of the next); then compound 4.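

In this assay, within the data shown here, the position next to the ring nitrogen turns out to be less forgiving than the earlier compounds suggested: placing (3-(pyrrolidin-1-yl)propyl)sulfanyl there gives a 21-fold higher number from compound 3 to compound 4 (1.33 log units; beyond the scatter) and also a 14-fold higher number from compound 1 to compound 4 (1.15 log units; beyond the scatter) on the same shared core, so the inhibitor is clearly weaker against either earlier chain. Isopentyloxy and butyl(methyl)amino lie within the scatter of each other, so the position does not accept every chain equally, and similar results from those two said little about a chain of a different kind. This single change swaps the atom attached to the ring for sulfur and also adds a nitrogen and a five-membered non-aromatic ring at the far end of the chain, and nothing available here explains why the number rises.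

The compounds shown leave open which of these differences matters, since all of them arrive together in compound 4. An isopentylsulfanyl chain would test the sulfur alone, while a 3-(pyrrolidin-1-yl)propoxy chain would test the ring-bearing end with oxygen attached to the core.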